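The source may report more compounds than this note shows. Statements on the series, on what has been measured and on what is new or still open speak of the compounds shown alone.

Measured so far:
Compound 1 `Cc1sc2nc(-c3ccccn3)c(/C=N/NC(=N)N)n2c1C` gives 37200 nM in a functional assay on ovarian cells (Homo sapiens) for antiproliferative activity; a lower number here means a stronger inhibitor of growth, a higher number a weaker inhibitor of growth.
Compound 2 `N=C(N)N/N=C/c1c(-c2ccccn2)nc2sc(Cl)cn12` gives 14500 nM in this assay.

Compound 1 stands as the higher of these two numbers, and compound 2 sits clearly beneath it, further apart than repeated tests of this kind usually scatter. Compound 3 `Cc1sc2nc(-c3ccncc3)c(/C=N/NC(=N)N)n2c1C` has not yet been measured. It differs from compound 1 in one place: pyridin-4-yl in place of pyridin-2-yl on an aromatic carbon. Among the measured compounds shown here, no measured pair shows what such a swap does here, so the step in this assay is expected to be small, in either direction, perhaps not beyond the scatter. The estimate for compound 3 is 50000 nM, between 15000 nM and 150000 nM. That expected change amounts to a 1.3-fold higher number from compound 1 to compound 3 (0.13 log units; within the scatter).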

Compound 3, concentration for total growth inhibition: 97700 nM
Compound 3: the middle estimate sits 2.0-fold (0.29 log units) below what was measured; the measured number falls inside the stated range.
By their numbers in this assay, from the lowest: compound 2; then compound 1; then compound 3.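

In this assay, putting pyridin-4-yl in place of pyridin-2-yl on this aromatic carbon gives a 2.6-fold higher number from compound 1 to compound 3 (0.42 log units; beyond the scatter) and so weakens growth inhibition modestly. Among the compounds shown here, the two groups have the same atoms and the same counts, so where the nitrogen sits within this ring matters here, a point the earlier compounds could not show. The data offer no measurement that explains this step.

Still open, going by these compounds, is how pyridin-3-yl or a plain phenyl ring would behave on this carbon. Also open, on these data alone, is whether pyridin-4-yl would raise the number for compound 2 as well.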